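The source may report more compounds than this note shows. Statements on the series, on what has been measured and on what is new or still open speak of the compounds shown alone.

Compound 1, `CC(C)=CCCC1=CC[C@H](C(=O)NO)[C@@H](c2ccccc2)C1`, gives 600 nM in an assay on isolated protein for inhibition of Apoptosis regulator Bcl-2 (Homo sapiens), read by fluorescence polarization, with stated times of 5 min and 10 min; a higher number here means a weaker inhibitor, a lower number a stronger inhibitor.
Compound 2, `CC(C)=CCCC1=CC[C@H](C(=O)NCCC(=O)O)[C@@H](c2ccccc2)C1`, gives > 23000 nM in this assay; this is a limit of the assay, not a number.
Compound 3, `CC(C)=CCCC1=CC[C@@H](C(=O)Nc2ccc(C(=O)O)cc2)[C@H](c2ccccc2)C1`, gives 2200 nM in this assay.

Within the data shown here, compound 2 therefore stands at the weak end of what has been measured, and only as a limit: its value sits at the limit of > 23000 nM in this assay, at which 1 of the 3 values shown sits, the one value of the three that carries no number. Among the measured compounds shown here, the single measured step that leads into compound 2 is an at least 38-fold higher number from compound 1 to compound 2 (1.58 log units; beyond the scatter), a large loss on exchanging hydroxy for 2-carboxyethyl on the amide-type nitrogen.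

Compound 4, `CC(C)=CCCC1=CC[C@H](C(=O)Nc2ccc(O)cc2)[C@@H](c2ccccc2)C1`, has not yet been measured in this assay. Its difference from compound 2 is 4-hydroxyphenyl in place of 2-carboxyethyl on an amide-type nitrogen. For the measured compounds named here, because the only step bearing on compound 2 is an at least 38-fold higher number from compound 1 to compound 2 (1.58 log units; beyond the scatter), which ran in the direction of weaker inhibition when 2-carboxyethyl entered, reversing out of that group is expected to recover potency. Compound 3, which carries 4-carboxyphenyl on an amide-type nitrogen, gives 2200 nM in this assay, a number rather than a limit, and compound 4 is expected to land in a similar region. The step of an at least 7.6-fold lower number from compound 2 to compound 4 (0.88 log units; beyond the scatter) is thus expected to be a clear decrease, with compound 4 estimated at 3000 nM, in the range 800 nM to 12000 nM.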

Compound 4, inhibition constant: > 23000 nM
Compound 4: no number, only a limit; the forecaster's own chance of this, stated with the estimate: 20%; middle value at least 7.6-fold (0.88 log units) away from the limit.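

In this assay, replacing hydroxy with 4-hydroxyphenyl on the amide-type nitrogen gives an at least 38-fold higher number from compound 1 to compound 4 (1.58 log units; beyond the scatter), so a second, quite different group now shows a large loss at this place, alongside an at least 38-fold higher number from compound 1 to compound 2 (1.58 log units; beyond the scatter). The step between the two replacements cannot be read, since both compounds stand only at a limit, and the data cannot rank 2-carboxyethyl against 4-hydroxyphenyl; the two now share the weak end of the series: the limit of > 23000 nM in this assay, at which 2 of the 4 values shown sit. Among the compounds with the stereochemistry drawn for compound 1, only the hydroxy compound gives a number, so an aromatic ring on this nitrogen does not by itself restore a measurable value.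

Compound 3 goes against any wider reading, since it carries an aromatic ring at this place and gives 2200 nM, but it also differs from compound 4 in its drawn stereochemistry, so the compounds shown cannot separate the effect of its 4-carboxyphenyl group from that of its stereochemistry. Also open, from the compounds shown here alone, is whether 4-carboxyphenyl with the stereochemistry of compound 4, or a 4-aminophenyl group on the same nitrogen, would give a number in this assay.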